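Chlorine moved on the aryl ring: solubility working notes

The compounds below may be only part of what the source reports. "The series", "measured", "known", "first", "only" and "open" are said of these compounds alone.

Compound 1 `CNC(=O)c1cc(C(=O)N[C@H]2CC[C@H](O)CC2)c([C@@H](C)c2ccc(Cl)cc2)o1` is the reference point for this step. In a physicochemical assay for solubility, measured as kinetic solubility (on this read-out lower numbers stand for lower solubility and higher numbers for higher solubility), compound 1 gives >= 118 ug/mL; this is a limit of the assay and not a number, so compound 1 stands at a bound rather than at a point on the scale. The line the limit of >= 118 ug/mL in this assay, at which 1 of the 2 values shown sits, records where that bound lies. Compound 2 `CC[C@@H](c1ccccc1)n1nc(C(=O)NC)cc1C(=O)N[C@H]1CC[C@H](O)CC1` is built on a different core, and in this assay compound 2 gives 138 ug/mL. Compound 3 `CNC(=O)c1cc(C(=O)N[C@H]2CC[C@H](O)CC2)c([C@@H](C)c2cccc(Cl)c2)o1` has not yet been measured in this assay. It differs from compound 1 only in 3-chlorophenyl in place of 4-chlorophenyl on a saturated chain carbon bound to an aromatic carbon and a saturated chain carbon, the two having the same atoms, joined differently. No measured pair in the set differs in one place, so nothing shows how a change of this kind moves this assay, and no cause can be drawn from the data. The step that the limit leaves unreadable from compound 1 to compound 3 is expected to fall within the scatter, with no direction assigned. Compound 3 is therefore estimated at 120 ug/mL, with a range from 55 ug/mL to 260 ug/mL, and a limit rather than a number is a likely outcome.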

Compound 3, solubility: >= 179 ug/mL
Compound 3 ended at the assay's limit; the forecaster's own chance of this, stated with the estimate: 60%; middle value at least 1.4-fold (0.17 log units) away from the limit.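

In this assay compound 1 gives >= 118 ug/mL, a limit of the assay and not a number. Compound 3 gives >= 179 ug/mL, also a limit. For the compounds shown here, no step from compound 1 to compound 3 can be read from these two limits. The compounds shown leave open where either true value lies, and whether 3-chlorophenyl in place of 4-chlorophenyl moves the read-out at all.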